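The compounds below may be only part of what the source reports. "The series", "measured", "known", "first", "only" and "open" are said of these compounds alone.

Compound 2 `CCCCN1CCC(C(=O)Nc2cc(Cl)c(N)cc2OC)CC1` stands at a limit rather than at a measured number. In a functional assay on the whole organism for antagonist activity, with Mus musculus as the target (a higher number here means that more compound is needed for the effect, a lower number that less compound is needed), compound 2 gives > 10 mg/kg, which is a limit of the assay. Compound 1 `CCCCCCN1CCC(C(=O)Nc2cc(Cl)c(N)cc2OC)CC1` likewise gives only a limit in this assay, namely > 10 mg/kg. The step that the two limits leave unreadable from compound 1 to compound 2 therefore cannot be read, since both values sit at the limit (the limit of > 10 mg/kg in this assay, at which 2 of the 2 values shown sit). Compound 3 `COc1cc(N)c(Cl)cc1NC(=O)C1CCN(CC2CCCCCC2)CC1` differs from compound 2 by cycloheptyl in place of propyl on a saturated chain carbon bound to an amine nitrogen in a ring. Going by the values given here, no measured step carries a readable size, so neither a direction nor a size can be drawn from them. Compound 3 is expected to give about 15 mg/kg, within 4 mg/kg to 60 mg/kg, most likely again as a limit. The expected step is a step that the limit leaves unreadable from compound 2 to compound 3.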

Compound 3, dose for half-maximal effect: > 10 mg/kg
Compound 3 ended at the assay's limit (the forecaster's own chance of this, stated with the estimate: 70%); the middle value is on the limit's open side.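

The steps among compound 1, compound 2 and compound 3 cannot be read, because all three values stand at a limit of the assay: the limit of > 10 mg/kg in this assay, at which 3 of the 3 values shown sit.

The compounds shown leave open whether these differences in the chain change the dose needed at all, and in which direction.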